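From Fluoro to Chloro at the Same Aromatic Carbon

The source may report more compounds than this note shows. Statements on the series, on what has been measured and on what is new or still open speak of the compounds shown alone.

Of the compounds shown here, three sharing one core have been tested in a functional assay on MDA-MB-231 cells (Homo sapiens) for inhibition, read by sulforhodamine B assay, with a stated time of 48 h, tested at 10 uM; a higher number here means more inhibition at the concentration tested (going by the name of the read-out), a lower number less inhibition. Compound 1, `COc1ccc(-c2cn3ccnc3c(-c3ccc4ncn(C5CCCCC5)c4c3)n2)cc1`, carries a methoxy group on its outer aromatic ring and gives 71.1%. Compound 2, `O=Cc1ccc(-c2cn3ccnc3c(-c3ccc4ncn(C5CCCCC5)c4c3)n2)cc1`, has a formyl group in place of that methoxy and gives 51.2%. Compound 3, `Fc1ccc(-c2cn3ccnc3c(-c3ccc4ncn(C5CCCCC5)c4c3)n2)cc1`, has a fluoro group there and gives 15.8%, the lowest of the three numbers; its nearest neighbour is compound 2 and its furthest is compound 1, both gaps beyond the scatter. All measured steps run downward toward compound 3: a number 19.9 percentage points lower from compound 1 to compound 2 (beyond the scatter), a number 55.3 percentage points lower from compound 1 to compound 3 (beyond the scatter) and a number 35.4 percentage points lower from compound 2 to compound 3 (beyond the scatter).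

Compound 4, `Clc1ccc(-c2cn3ccnc3c(-c3ccc4ncn(C5CCCCC5)c4c3)n2)cc1`, differs from compound 3 in one place: chloro in place of fluoro on an aromatic carbon. For the measured compounds named here, none of the measured steps replaces fluoro with another group; each swaps a methoxy or formyl group, so they show how much this position can move the number but give no direction for this particular exchange. Since compound 3 already sits at the bottom, a further fall has less room than a rise. The expected step is a number 9.2 percentage points higher from compound 3 to compound 4 (within the scatter), a modest rise that may not exceed the scatter. The estimated value for compound 4 in this assay is 25%, within a range from 5% to 50%.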

Compound 4, a percentage reported as inhibition, at one concentration (the size of the read-out at that concentration, not a potency): 15.3%
The estimate for compound 4 lay 9.7 percentage points above the measured number; measured number inside the range.
By their numbers in this assay, from the lowest: compounds 4 and 3 (each within the scatter of the next); then compound 2; then compound 1.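

In this assay, for the compounds shown here, chloro in place of fluoro is the first exchange at this aromatic carbon that stays within the scatter (a number 0.5 percentage points lower from compound 3 to compound 4 (within the scatter)), so the 4-fluorophenyl and 4-chlorophenyl compounds cannot be told apart here, whereas every earlier step at this carbon went beyond it. The gaps to the other two groups are large and beyond the scatter (a number 35.9 percentage points lower from compound 2 to compound 4 (beyond the scatter) and a number 55.8 percentage points lower from compound 1 to compound 4 (beyond the scatter)), which means that the low end of the numbers at this position now rests on two compounds with different halogens rather than on fluoro alone. Nothing available explains why these two groups give such similar numbers, or why formyl and methoxy stand apart from them.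

Only four groups at this carbon are shown, so it remains open whether a bromo group, a methyl group, an amine or a carboxylic acid would fall with the two halogens or nearer to formyl and methoxy. Each number also comes from a single concentration, which leaves open how the four compounds would compare in potency.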